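Sulfonyl aryl variation in the trifluoromethyl hydroxyamide series

The source may report more compounds than this note shows. Statements on the series, on what has been measured and on what is new or still open speak of the compounds shown alone.

Compound 1 `CC(O)(C(=O)Nc1ccc(S(=O)(=O)c2ccccc2C#N)cc1)C(F)(F)F` and compound 2 `CC(O)(C(=O)Nc1ccc(S(=O)(=O)c2cccnc2)cc1)C(F)(F)F` share the same core and differ only in the ring on the sulfonyl sulfur. In a functional assay (Cavia porcellus) with sulfonylurea receptors; K-ATP channels (Homo sapiens) as the target (a higher number here means a weaker inhibitor, a lower number a stronger inhibitor), compound 1 gives 1100 nM and compound 2 gives 3500 nM. Within the data shown here, compound 2 thus carries the higher of the two numbers so far, its nearest neighbour being compound 1; the step of a 3.2-fold higher number from compound 1 to compound 2 (0.50 log units; beyond the scatter) shows that the ring on the sulfonyl sulfur matters for this assay, with the pyridin-3-yl ring giving the weaker inhibitor.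

Compound 3 `CC(O)(C(=O)Nc1ccc(S(=O)(=O)c2cncnc2)cc1)C(F)(F)F` continues in the same place: pyrimidin-5-yl in place of pyridin-3-yl on a sulfonyl sulfur. Among the measured compounds shown here, no measured pair reports the effect of a second ring nitrogen here, so the only bearing step is the one from compound 1 to compound 2, which was modest and went towards weaker inhibition when a ring nitrogen was introduced. A further modest move in the same direction, or at most one at the edge of the scatter, is therefore expected; the step is estimated as a 1.6-fold higher number from compound 2 to compound 3 (0.20 log units; within the scatter). For compound 3 in this assay the estimate is 5500 nM, within a range of 2500 nM to 12000 nM.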

Compound 3, half-maximal inhibitory concentration: > 30000 nM
Compound 3 ended at the assay's limit; the forecaster's own chance of this, stated with the estimate: 5%; middle value at least 5.4-fold (0.73 log units) away from the limit.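

In this assay, compound 3 stands at a limit of the assay and not at a number: the limit of > 30000 nM in this assay, at which 1 of the 3 values shown sits.

Pyrimidin-5-yl in place of pyridin-3-yl gives an at least 8.5-fold higher number from compound 2 to compound 3 (0.93 log units; beyond the scatter), so a single exchange of a ring carbon for a ring nitrogen on the sulfonyl sulfur is enough to reach that limit. Against the 2-cyanophenyl ring, the same pyrimidin-5-yl ring gives an at least 27-fold higher number from compound 1 to compound 3 (1.43 log units; beyond the scatter), which shows that this position spans a large range, with the three rings falling in the order 2-cyanophenyl, pyridin-3-yl, pyrimidin-5-yl from stronger to weaker inhibition.

From the compounds shown here alone, how far the true value of compound 3 lies past the limit stays open, so both new steps give only a lower bound on the size of the change. Also open, going by these compounds, is what the ring nitrogens contribute on their own, since the earlier exchange removes the nitrile and brings in a ring nitrogen at once; an unsubstituted phenyl ring, or a pyridin-3-yl ring carrying a nitrile, on the sulfonyl sulfur would separate the two.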